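The source may hold more compounds than are shown below. What is called first, only, known or untested is meant among the compounds shown, and "the series" means these compounds.

Measured so far:
- compound 1 `CCn1cc(C(=O)O)c(=O)c2cc(F)c(N3CCN(C(=N)NS(=O)(=O)c4ccc(C(F)(F)F)cc4)CC3)cc21`: 32 nM
- compound 2 `N=C(NS(=O)(=O)c1ccccc1)N1CCN(c2cc3c(cc2F)c(=O)c(C(=O)O)cn3C2CC2)CC1`: 32 nM

In a functional assay on HeLa cells (Homo sapiens) for antiproliferative activity, read by MTT assay, with a stated time of 72 h (on this read-out higher numbers stand for weaker inhibition and lower numbers for stronger inhibition), compound 2 gives 32 nM, level with compound 1 at 32 nM at the digits shown, and the difference between them lies within the scatter.

The next compound is compound 3 `Cc1ccc(S(=O)(=O)NC(=N)N2CCN(c3cc4c(cc3F)c(=O)c(C(=O)O)cn4C3CC3)CC2)cc1`, which differs from compound 2 as follows: methyl in place of hydrogen on an aromatic carbon. This is methyl in place of hydrogen on an aromatic carbon, para to a large group, or phenyl to 4-methylphenyl. Among the measured compounds shown here, no measured pair isolates this change, so the data give no direct precedent for its size or direction. In this assay no step beyond the scatter is expected, and no direction is favoured. The expected change is a 1.1-fold higher number from compound 2 to compound 3 (0.04 log units; within the scatter), an estimate that stays within the scatter. For compound 3 the estimated value is 35 nM, with an expected range of 12 nM to 100 nM.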

Compound 3, half-maximal inhibitory concentration: 32 nM
Compound 3: middle estimate off by 1.1-fold (0.04 log units), on the high side, and the stated range covers the measured number.
By their numbers in this assay, from the lowest: compounds 1, 2 and 3 (each within the scatter of the next).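

Phenyl to 4-methylphenyl, with the methyl para to a large group, gives in this assay no change at the digits printed from compound 2 to compound 3 (within the scatter) and is the first pair in the series to isolate a single change at this ring. In this one pair, a single added carbon at this place does not move the number beyond the scatter, though one pair sets no general rule for the series. No measurement shown offers an explanation for this result.

From the compounds shown here alone, whether an amine, a carboxylic acid or a longer chain such as propyl at the same place would also stay within the scatter remains open. The trifluoromethyl group of compound 1 cannot be compared directly with the methyl group of compound 3, as those compounds differ in more than one place.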